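The source may hold more compounds than are shown below. What is called first, only, known or untested is meant among the compounds shown, and "the series" means these compounds.

In a functional assay on THP-1 cells (Homo sapiens) for antiproliferative activity, read by MTT assay, with a stated time of 72 h (on this read-out higher numbers stand for weaker inhibition of growth and lower numbers for stronger inhibition of growth), compound 1 `Cc1ccc(Cl)cc1-n1nnc(C(=O)Nc2ccc(SC#N)cc2)c1C` gives > 100000 nM, a limit of the assay and not a number. Compound 2 `Cc1ccc(Cl)c(-n2nnc(C(=O)Nc3ccc(SC#N)cc3)c2C)c1` gives > 100000 nM, also a limit. The evidence so far is the limit of > 100000 nM in this assay, at which 2 of the 2 values shown sit. Within the data shown here, the only measured step is a step that the two limits leave unreadable from compound 1 to compound 2, so no size can be carried forward from it. Compound 3 `COc1cccc(-n2nnc(C(=O)Nc3ccc(SC#N)cc3)c2C)c1` has 3-methoxyphenyl in place of 2-chloro-5-methylphenyl on an aromatic nitrogen. Growth inhibition is expected to stay weak, with any shift toward stronger inhibition expected to be modest. The expected change is an at least 1.2-fold lower number from compound 2 to compound 3 (0.09 log units; that floor lies within the scatter) in this assay. For compound 3, the estimate is 80000 nM, with an expected range from 15000 nM to 150000 nM.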

Compound 3, concentration for 50% growth inhibition: > 100000 nM
Compound 3: a limit, no number (the forecaster's own chance of this, stated with the estimate: 65%); middle value at least 1.2-fold (0.09 log units) away from the limit.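

Compound 1, compound 2 and compound 3 all stop at the same limit of the assay, so no step among them can be read: the limit of > 100000 nM in this assay, at which 3 of the 3 values shown sit.

What the compounds shown leave open is how strongly any of them inhibits growth, and whether changing the group on the aromatic nitrogen alters that at all.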